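The source may hold more compounds than are shown below. What is called first, only, known or untested is meant among the compounds shown, and "the series" means these compounds.

Measured so far in a functional assay on C6 cells (Rattus norvegicus) for cytotoxicity, read by MTT assay, with a stated time of 24 h, tested at 25 ug/mL; on this read-out higher numbers stand for a weaker effect at the one concentration tested and lower numbers for a stronger effect:
compound 1 `Cc1nnc(SCC(=O)N/N=c2/scc(-c3ccc(Cl)cc3)n2-c2ccccc2)s1` gives 53.3%
compound 2 `Cn1nnnc1SCC(=O)N/N=c1/scc(-c2ccc([N+](=O)[O-])cc2)n1-c1ccccc1` gives 69.3%
compound 3 `O=C(CSc1ncccn1)N/N=c1/scc(-c2ccc(Cl)cc2)n1-c1ccccc1` gives 91.1%

Compound 1 stands lowest of the three numbers in this assay, that is, it shows the strongest effect at the one concentration tested; compound 2 is the nearest and compound 3 the furthest, both beyond the scatter. For the measured compounds named here, the one step between compounds differing in a single place, a number 37.8 percentage points higher from compound 1 to compound 3 (beyond the scatter), concerns the group on the sulfur and is large. Compound 4 `Cc1ccc(-c2cs/c(=N/NC(=O)CSc3nnc(C)s3)n2-c2ccccc2)cc1` differs from compound 1 elsewhere: methyl in place of chloro on an aromatic carbon. Going by the values given here, no measured step touches this part of the shared core. Among the compounds with values here, compound 2 differs from compound 1 in two places at once, so its values show only that a changed group on that ring can go together with a higher number. With nothing bearing directly on the change, no step beyond the scatter is expected in this assay, the step of a number 4.7 percentage points higher from compound 1 to compound 4 (within the scatter) being an estimate only. Compound 4 is therefore expected near 58%, within 40% to 78%.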

Compound 4, a percentage reported as activity, at one concentration (the size of the read-out at that concentration, not a potency): 50.1%
The estimate for compound 4 lay 7.9 percentage points above the measured number, within the range that was stated.
By their numbers in this assay, from the lowest: compounds 4 and 1 (each within the scatter of the next); then compound 2; then compound 3.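

In this assay, for the compounds shown here, the change from 4-chlorophenyl to 4-methylphenyl gives a number 3.2 percentage points lower from compound 1 to compound 4 (within the scatter), the one reading of this position with nothing else changed, as compound 2 differs from compound 1 in two places at once. At this position, on an aromatic carbon para to a large group, chloro and methyl cannot be told apart in this assay, whereas the group on the sulfur gives a number 37.8 percentage points higher from compound 1 to compound 3 (beyond the scatter). No measurement at hand bears on the reason for this result.

On these data alone, what an amine or a carboxylic acid at this position would give stays open. Also open, as far as these compounds go, is whether chloro and methyl would still match with the pyrimidin-2-yl group of compound 3 on the sulfur.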